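This account rests on a few compounds, and the source may have more. Where it says the series, first, only, none or still open, it means among the compounds named here.

Compound 1 `CC(C)c1ccc(NC(=O)N[C@H](C)c2ccccc2)cc1` gives 99% in an ADME assay on the whole organism with Oryza sativa as the target, tested at 0.1 uM (on this read-out higher numbers stand for a weaker effect at the one concentration tested and lower numbers for a stronger effect), and stands level with compound 3 `CCCCCCc1ccc(NC(=O)N[C@@H](C)c2ccccc2)cc1`, which gives 99%; together they hold the highest of the three numbers. Compound 2 `CC(C)c1ccc(NC(=O)N[C@@H](C)c2ccccc2)cc1` gives 98%, the furthest from compound 1, the step being a number 1 percentage points lower from compound 1 to compound 2 (within the scatter); the two are separated only by the fact that compounds 1 and 2 differ only in the configuration as drawn.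

The change to compound 4 `CCCCCCCc1ccc(NC(=O)N[C@H](C)c2ccccc2)cc1` is heptyl in place of isopropyl on an aromatic carbon. Among the measured compounds shown here, the one measured step of the same kind, a longer chain for isopropyl on the aromatic carbon, is a number 1 percentage points higher from compound 2 to compound 3 (within the scatter). Both measured steps sit within the scatter, so for compound 4 no step beyond the scatter is expected in this assay, and the expected step is no change at the digits printed from compound 1 to compound 4 (within the scatter). Compound 4 is estimated at 99%, between 94% and 100%.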

Compound 4, a percentage reported as activity, at one concentration (the size of the read-out at that concentration, not a potency): 100%
For compound 4 the middle estimate is 1 percentage points below the measured one; the range from low to high includes it.
By their numbers in this assay, from the lowest: compounds 2, 1, 3 and 4 (each within the scatter of the next).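

In this assay, heptyl in place of isopropyl on an aromatic carbon gives a number 1 percentage points higher from compound 1 to compound 4 (within the scatter). Among the compounds shown here, the exchange of isopropyl for a longer chain at this position therefore stays within the scatter with the configuration of compound 1 as well, whereas the earlier step covered only that of compound 2. The data on hand give no cause for this step.

No change among the compounds shown lies beyond the scatter, so what would move this read-out remains open. Whether an amine or a carboxylic acid at this position would shift the number is also unresolved.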